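The source may report more compounds than this note shows. Statements on the series, on what has been measured and on what is new or still open speak of the compounds shown alone.

Measured so far:
- compound 1, `NCC1=C(CN(C[C@H]2Cc3ccccc3CN2)[C@H]2CCCc3cccnc32)CCCC1`, 230 nM
- compound 2, `N[C@H]1CC[C@H](N(C[C@H]2Cc3ccccc3CN2)[C@H]2CCCc3cccnc32)CC1`, 34 nM

Within the data shown here, compound 2 holds the lowest of the two numbers in a functional assay on CCRF-CEM cells for antagonist activity at C-X-C chemokine receptor type 4 (Homo sapiens), read by calcium flux, with stated times of 25 min and 90 s; a higher number here means a weaker inhibitor, a lower number a stronger inhibitor; its nearest neighbour is compound 1, and the only step in the set, a 6.8-fold lower number from compound 1 to compound 2 (0.83 log units; beyond the scatter), separates them. Compound 3, `N[C@H]1CC[C@@H](N(C[C@H]2Cc3ccccc3CN2)[C@H]2CCCc3cccnc32)CC1`, is the next compound to be measured. Its relation to compound 2 is the two compounds have the same atoms and bonds and differ only in configuration as drawn: 2 of 4 stereo elements differ; a stereocentre at a saturated ring carbon is drawn S in compound 2 and R in compound 3; a stereocentre at a saturated ring carbon is drawn r in compound 2 and s in compound 3. Among the measured compounds shown here, no measured step bears on this kind of change: the one known step, a 6.8-fold lower number from compound 1 to compound 2 (0.83 log units; beyond the scatter), swaps one group for another, and nothing in the set shows what turning the configuration of the 4-aminocyclohexyl does in this assay. The expectation for compound 3 therefore rests on compound 2 alone, with a wide range, and the step of a 2.1-fold higher number from compound 2 to compound 3 (0.31 log units; beyond the scatter) is an estimate, not a measured value. Compound 3 is estimated at 70 nM, between 20 nM and 250 nM.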

Compound 3, half-maximal inhibitory concentration: 1800 nM
Compound 3: the middle estimate sits 26-fold (1.41 log units) below what was measured; measured number above the stated range.
By their numbers in this assay, from the lowest: compound 2; then compound 1; then compound 3.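

The configuration of the 4-aminocyclohexyl weighs heavily in this assay: the set now holds a 53-fold higher number from compound 2 to compound 3 (1.72 log units; beyond the scatter) as a large step, and this gap can come from configuration alone: the fact that compounds 2 and 3 differ only in the configuration as drawn. The swap of (2-(aminomethyl)cyclohex-1-en-1-yl)methyl for 4-aminocyclohexyl also proves to have no single direction, giving a 6.8-fold lower number from compound 1 to compound 2 (0.83 log units; beyond the scatter) with one configuration but a 7.8-fold higher number from compound 1 to compound 3 (0.89 log units; beyond the scatter) with the other. The gain seen earlier therefore belongs to the configuration of compound 2 and not to the 4-aminocyclohexyl as such.

The compounds shown leave open whether the amine on the cyclohexyl ring is needed at all, and whether a hydroxyl or a dimethylamine in its place would show the same dependence on configuration. They also leave open whether an aminomethyl group on that ring would keep this large gap between the two configurations.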